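A few compounds are considered here, and "the series" means these few. Any claim that something is new, unique, unknown or untested is made for them only; others in the source may bear on it.

In a functional assay on KB cells (Homo sapiens) for antiproliferative activity, read by sulforhodamine B assay, with a stated time of 72 h (on this read-out lower numbers stand for stronger inhibition and higher numbers for weaker inhibition), compound 1 (`COc1ccc(/C=C2\CCC=CC2=O)cc1`) gives 1560 nM. Going by the values given here, the only other measured compound, compound 2 (`COc1ccc(/C=C2\CCC=CC2=O)cc1OC`), gives 900 nM, so the two values lie within the usual scatter of each other and compound 1 cannot be firmly ranked. The next compound, compound 3 (`COc1ccc(/C=C2\CCC=CC2=O)c(C)c1`), keeps the core of compound 1 and differs in one place: methyl in place of hydrogen on an aromatic carbon. Among the compounds with values here, no measured step adds a methyl. The closest guide is methoxy in place of hydrogen on an aromatic carbon, which gives a 1.7-fold lower number from compound 1 to compound 2 (0.24 log units; within the scatter). That step involves a different group, so it bears on this change only loosely. It suggests no step beyond the scatter in this assay, and no direction can be favoured with confidence. The expected step is a 1.2-fold lower number from compound 1 to compound 3 (0.08 log units; within the scatter). For compound 3 the estimated value is 1300 nM, with an expected range from 550 nM to 3000 nM.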

Compound 3, half-maximal inhibitory concentration: 1310 nM
Beside the measured number, compound 3's estimate is 1.0-fold (0.00 log units) below it; the range from low to high includes it.
By their numbers in this assay, from the lowest: compounds 2, 3 and 1 (each within the scatter of the next).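

In this assay, methyl in place of hydrogen on an aromatic carbon gives a 1.2-fold lower number from compound 1 to compound 3 (0.08 log units; within the scatter) and so does not separate the two compounds. Going by these compounds alone, this is the first look at this place on the ring, ortho to a group of 8 heavy atoms and meta to a methoxy group, and a single added carbon there leaves the number within the scatter of compound 1. No measurement is available that could explain this result.

As far as these compounds go, whether a longer chain such as propyl, or a group of another kind such as an amine or a carboxylic acid, would shift the number beyond the scatter at this place remains open. One small group at one place also cannot show how much change this position allows in general.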